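Cyclopropyl for ethyl on the chain carbon: rat exposure notes

A few compounds are considered here, and "the series" means these few. Any claim that something is new, unique, unknown or untested is made for them only; others in the source may bear on it.

Measured so far:
compound 1 `C=CCNC(=O)C(=O)C(CC1CC1)NC(=O)[C@@H]1CC2(CN1C(=O)[C@@H](NC(=O)N[C@@H](CN1C(=O)CC(C)(C)CC1=O)C(C)(C)C)C1(C)CCCCC1)SCCS2` — 161 ng.h/mL
compound 2 `C=CCNC(=O)C(=O)C(CCC)NC(=O)[C@@H]1CC2(CN1C(=O)[C@@H](NC(=O)N[C@@H](CN1C(=O)CC(C)(C)CC1=O)C(C)(C)C)C1(C)CCCCC1)SCCS2` — 31.6 ng.h/mL
compound 3 `C=CCNC(=O)C(=O)C(CCC)NC(=O)[C@@H]1CC2(CN1C(=O)[C@@H](NC(=O)NC1(CS(=O)(=O)C(C)(C)C)CCCCC1)C(C)(C)C)SCCS2` — 424 ng.h/mL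

In an ADME assay on the whole organism (plasma) for pharmacokinetics, with Rattus norvegicus as the target, at a dose of 10 mg/kg by the oral route (a higher number here means more compound in the circulation at the dose given, a lower number less compound in the circulation), compound 2 gives 31.6 ng.h/mL, while compound 1 gives 161 ng.h/mL. The step of a 5.1-fold higher number from compound 2 to compound 1 (0.71 log units; beyond the scatter) goes with cyclopropyl in place of ethyl on a saturated chain carbon, two bonds along the chain from an amide-type nitrogen and a carbonyl carbon. Compound 3 gives 424 ng.h/mL, the highest number of the three; the difference between its core and that of compound 2 is not broken down here. Compound 4 `C=CCNC(=O)C(=O)C(CC1CC1)NC(=O)[C@@H]1CC2(CN1C(=O)[C@@H](NC(=O)NC1(CS(=O)(=O)C(C)(C)C)CCCCC1)C(C)(C)C)SCCS2` carries the same change on the core of compound 3, namely (cyclopropyl in place of ethyl on a saturated chain carbon, two bonds along the chain from an amide-type nitrogen and a carbonyl carbon). For the measured compounds named here, for compound 4 a step of a 3.3-fold higher number from compound 3 to compound 4 (0.52 log units; beyond the scatter) is expected in this assay, because the same change once gave a 5.1-fold higher number from compound 2 to compound 1 (0.71 log units; beyond the scatter); the step is taken somewhat smaller, since only one earlier instance exists and compound 3 already stands high. Compound 4 is therefore estimated at 1400 ng.h/mL, with a range from 500 ng.h/mL to 4000 ng.h/mL.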

Compound 4, area under the concentration-time curve: 582 ng.h/mL
For compound 4 the middle estimate is 2.4-fold (0.38 log units) above the measured one, and the stated range covers the measured number.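

In this assay the change of ethyl to cyclopropyl on the core of compound 3 gives a 1.4-fold higher number from compound 3 to compound 4 (0.14 log units; within the scatter). The step therefore does not carry over at the same size from one core to the other: the same change on two cores in this assay, a 5.1-fold higher number (0.71 log units; beyond the scatter) from compound 2 to compound 1 and a 1.4-fold higher number (0.14 log units; within the scatter) from compound 3 to compound 4, 3.7-fold (0.57 log units) apart, beyond the scatter of two such steps

With one pair on each core, this shows that the size of the step depends on the core in these two pairs, but it sets no rule for a third core and does not show which difference between the cores goes with the smaller step. The compounds shown leave open how a longer chain such as butyl, or a cyclobutylmethyl group in place of propyl, would behave on either core.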